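Replacing a substituted phenyl with a hydroxypyridinyl group

A few compounds are considered here, and "the series" means these few. Any claim that something is new, unique, unknown or untested is made for them only; others in the source may bear on it.

Three compounds share a common core. Compound 1 `O=C(O)Cc1sc(C(c2ccccc2)c2ccc(F)cc2)nc1-c1ccc(Cl)cc1` gives 17 nM in an in vitro assay on HEK385-7 cells for displacement of a labelled ligand from prostaglandin D2 receptor 2 (Homo sapiens) (a lower number here means a stronger inhibitor, a higher number a weaker inhibitor), compound 2 `O=C(O)Cc1sc(C(c2ccccc2)c2ccccc2)nc1-c1ccc(F)c(F)c1` gives 4.1 nM, and compound 3 `N#Cc1cc(-c2nc(C(c3ccc(F)cc3)c3ccc(F)cc3)sc2CC(=O)O)ccc1F` gives 57 nM, the highest of the three, with its neighbour compound 1 beyond the scatter and compound 2 further still. Compound 4 `O=C(O)Cc1sc(C(c2ccc(F)cc2)c2ccc(F)cc2)nc1-c1ccnc(O)c1` is not yet measured. It differs from compound 3 in one place: 2-hydroxypyridin-4-yl in place of 3-cyano-4-fluorophenyl on an aromatic carbon. For the measured compounds named here, no measured pair tracks this change. The three aryl groups already seen on this position span a wide range, so a step of uncertain direction is expected, most likely a modest weakening in a 1.8-fold higher number from compound 3 to compound 4 (0.24 log units; within the scatter). Compound 4 is therefore estimated at 100 nM, within 30 nM to 350 nM.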

Compound 4, half-maximal inhibitory concentration: 68 nM
The estimate for compound 4 lay 1.5-fold (0.17 log units) above the measured number; the measured number falls inside the stated range.
By their numbers in this assay, from the lowest: compound 2; then compound 1; then compounds 3 and 4 (each within the scatter of the next).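

In this assay the exchange of 3-cyano-4-fluorophenyl for 2-hydroxypyridin-4-yl is a 1.2-fold higher number from compound 3 to compound 4 (0.08 log units; within the scatter) and lies within the scatter. For the compounds shown here, this is the first step at this position that can be read in one place, and it shows that the position tolerates a ring with a hetero atom and a hydrogen-bond donor in place of the nitrile-bearing ring. Nothing shown explains why the two groups read alike. Still open, going by these compounds, is whether a plain pyridin-4-yl or a 2-methoxypyridin-4-yl group would read the same. Also open, on these data alone, is whether 2-hydroxypyridin-4-yl would hold up on the core of compound 2.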